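The compounds below may be only part of what the source reports. "The series", "measured", "known", "first", "only" and "open" are said of these compounds alone.

Compound 1 `ClCc1cccc(Cn2cnc3ncnc(Cl)c32)c1` gives 4070 nM in a functional assay on 786-0 cells (Homo sapiens) for cytotoxicity, read by sulforhodamine B assay, with a stated time of 48 h; on this read-out higher numbers stand for weaker inhibition of growth and lower numbers for stronger inhibition of growth.
Compound 2 `ClCc1cccc(Cn2cnc3c(Cl)ncnc32)c1` gives 20000 nM in this assay.
Compound 3 `ClCc1cccc(Cn2cnc3c(Cl)nc(Cl)nc32)c1` gives 26900 nM in this assay.

Among these three, compound 1 stands lowest, and its gaps to compound 2 and to compound 3 are both beyond the usual scatter, so compound 1 is the strongest inhibitor of growth of the set. The step to compound 4 `ClCc1cccc(Cn2cnc3nc(Cl)nc(Cl)c32)c1` is a single change on the core of compound 1: chloro in place of hydrogen on an aromatic carbon. Going by the values given here, one measured step bears on it, the same kind of change from compound 2 to compound 3, where a chloro group also took the place of a hydrogen on an aromatic carbon; that step was a 1.3-fold higher number from compound 2 to compound 3 (0.13 log units; within the scatter). On that basis, adding a chloro group to compound 1 is expected to move the number little, if at all, perhaps slightly upward. Compound 4 is therefore estimated at 5500 nM, with a range from 2500 nM to 13000 nM, which means an expected step of a 1.4-fold higher number from compound 1 to compound 4 (0.13 log units; within the scatter).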

Compound 4, concentration for total growth inhibition: 2880 nM
Compound 4: middle estimate off by 1.9-fold (0.28 log units), on the high side; the range from low to high includes it.
By their numbers in this assay, from the lowest: compounds 4 and 1 (each within the scatter of the next); then compounds 2 and 3 (each within the scatter of the next).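

In this assay, the chloro group on the aromatic carbon between two ring nitrogen atoms gives a 1.4-fold lower number from compound 1 to compound 4 (0.15 log units; within the scatter). Going by these compounds alone, until now this change had been seen only on the core of compound 2; it now also leaves the number within the scatter on the core of compound 1, the core with the lowest number among the earlier compounds. The two steps point in opposite directions on paper, but they cannot be told apart, so the two cores give no sign of responding differently to this change: the same change on two cores in this assay, a 1.3-fold higher number (0.13 log units; within the scatter) from compound 2 to compound 3 and a 1.4-fold lower number (0.15 log units; within the scatter) from compound 1 to compound 4, 1.9-fold (0.28 log units) apart, within the scatter of two such steps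

Hydrogen and chloro are the only two groups shown at this position, so it remains open whether a larger change would move the number beyond the scatter. An amine or a methoxy group in place of the chloro group of compound 4 would test that.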